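Amide replacement in a thyroid hormone receptor beta antagonist series

The source may report more compounds than this note shows. Statements on the series, on what has been measured and on what is new or still open speak of the compounds shown alone.

Measured compounds:
compound 1, `CC1(C)CC2CC(C)(CN2C(=O)c2sc(-c3ccc(S(C)(=O)=O)c([N+](=O)[O-])c3)nc2C(F)(F)F)C1`, 2100 nM
compound 2, `CC1Cc2ccccc2N1C(=O)c1sc(-c2ccc(S(C)(=O)=O)c([N+](=O)[O-])c2)nc1C(F)(F)F`, 5200 nM

Both values come from a functional assay for antagonist activity at thyroid hormone receptor beta (Homo sapiens), read by fluorescence polarization, with a stated time of 3 h; on this read-out lower numbers stand for stronger inhibition and higher numbers for weaker inhibition. Compound 1 stands lowest of the two numbers; its nearest neighbour is compound 2, reached by a 2.5-fold higher number from compound 1 to compound 2 (0.39 log units; beyond the scatter), a modest step beyond the scatter that follows a change of the group on the carbonyl carbon.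

Compound 3, `CC1CCN(C(=O)c2sc(-c3ccc(S(C)(=O)=O)c([N+](=O)[O-])c3)nc2C(F)(F)F)CC1`, is not yet measured. It differs from compound 1 as follows: a group of 7 heavy atoms (6 carbon, 1 nitrogen; one six-membered non-aromatic ring with 1 hetero atom) in place of a group of 11 heavy atoms (10 carbon, 1 nitrogen; one five-membered non-aromatic ring with 1 hetero atom, one six-membered non-aromatic ring of carbon only), on a carbonyl carbon. Among the compounds with values here, the only measured step that bears on this change is the one from compound 1 to compound 2, which also alters the group on the carbonyl carbon and gave a modest rise in this assay. A change at the same place in compound 3 is therefore expected to give a step of similar size in the same direction, a 1.9-fold higher number from compound 1 to compound 3 (0.28 log units; within the scatter). The estimated value for compound 3 is 4000 nM, with a range from 1500 nM to 12000 nM.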

Compound 3, half-maximal inhibitory concentration in the thyroid hormone receptor beta assay: 310 nM
Compound 3: the middle estimate sits 13-fold (1.11 log units) above what was measured, and the stated range ends above it.
By their numbers in the thyroid hormone receptor beta assay, from the lowest: compound 3; then compound 1; then compound 2.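

In the thyroid hormone receptor beta assay, a change of the group on this carbonyl carbon can also lower the number: a 6.8-fold lower number from compound 1 to compound 3 (0.83 log units; beyond the scatter), and a 17-fold lower number from compound 2 to compound 3 (1.22 log units; beyond the scatter). The 4-methylpiperidin-1-yl group of compound 3 has the fewest heavy atoms of the three groups and gives the lowest number, but heavy-atom count alone does not order the series: compound 2 has fewer heavy atoms in this group than compound 1, yet the higher number. In a physicochemical assay for solubility, in phosphate buffer, at pH 7.4 (on this read-out lower numbers stand for lower solubility and higher numbers for higher solubility), compound 1 gives 1000 nM, and compound 3 gives 6400 nM. The lower number in compound 3 also comes with a higher number in the physicochemical assay: the measured solubility of compound 1, 1000 nM, and of compound 3, 6400 nM, a 6.4-fold higher number (0.81 log units; beyond the scatter)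

The compounds shown leave open whether the step belongs to the six-membered ring or to its methyl group. Piperidin-1-yl without the methyl group would separate the two, and morpholin-4-yl would test a second ring hetero atom.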